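Compound 3 to compound 4: 3-nitrophenyl replaces 2,4-dichlorophenyl

The compounds below may be only part of what the source reports. "The series", "measured", "known", "first", "only" and "open" are said of these compounds alone.

In a functional assay on K562 cells (Homo sapiens) for cytotoxicity, read by MTT assay, with a stated time of 24 h (a lower number here means a stronger inhibitor, a higher number a weaker inhibitor), compound 1 (`COc1cc(/C=C2\CN(C)C/C(=C\c3cccc([N+](=O)[O-])c3)C2=O)cc(OC)c1`) gives 4420 nM. Compound 2 (`COc1cc(/C=C2\CN(C)C/C(=C\c3ccc(Cl)cc3)C2=O)cc(OC)c1OC`) stands at > 20000 nM, which is a limit. Compound 3 (`COc1cc(/C=C2\CN(C)C/C(=C\c3ccc(Cl)cc3Cl)C2=O)cc(OC)c1OC`) stands at > 20000 nM, also a limit. Compound 3 therefore has no number of its own, and the series shows (the limit of > 20000 nM in this assay, at which 2 of the 3 values shown sit).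

Compound 4 (`COc1cc(/C=C2\CN(C)C/C(=C\c3cccc([N+](=O)[O-])c3)C2=O)cc(OC)c1OC`) keeps the core of compound 3 and changes one group: 3-nitrophenyl in place of 2,4-dichlorophenyl on a double-bonded chain carbon bound to a double-bonded ring carbon. In words, this is 3-nitrophenyl in place of 2,4-dichlorophenyl on a double-bonded chain carbon bound to a double-bonded ring carbon.

For the measured compounds named here, the only measured step between close neighbours, a step that the two limits leave unreadable from compound 2 to compound 3, has no readable size, so it provides no magnitude to carry over. The nearest guide is compound 1, which carries the 3-nitrophenyl group and gives 4420 nM, although its core differs from that of compound 4. Against this, compound 2 and compound 3 share the core of compound 4 and neither has given a number.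

A move towards stronger inhibition is therefore expected, with a reading still at the limit remaining possible. The expected change is an at least 2.2-fold lower number from compound 3 to compound 4 (0.34 log units; beyond the scatter). For compound 4 the estimate is 9000 nM, with an expected range of 3000 nM to 20000 nM.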

Compound 4, half-maximal inhibitory concentration: 4200 nM
Compound 4: the middle estimate sits 2.1-fold (0.33 log units) above what was measured; low and high end bracket the measured number.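

In this assay, the place on a double-bonded chain carbon bound to a double-bonded ring carbon now gives a readable result on the shared core: an at least 4.7-fold lower number from compound 3 to compound 4 (0.67 log units; beyond the scatter), and an at least 4.7-fold lower number from compound 2 to compound 4 (0.67 log units; beyond the scatter), both for 3-nitrophenyl in place of a chlorinated phenyl. The values of compound 2 and compound 3 are limits, so these two sizes are only floors: the limit of > 20000 nM in this assay, at which 2 of the 4 values shown sit.

The third step, a 1.1-fold lower number from compound 1 to compound 4 (0.02 log units; within the scatter), for the added methoxy group, lies within the scatter, so with 3-nitrophenyl at this place the two cores read alike, which the chlorinated compounds alone could not show.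

On these data alone, the true size of the gain stays open, as does any ranking of 4-chlorophenyl against 2,4-dichlorophenyl, since the step between those two cannot be read. It also remains open whether the nitro group itself carries the result, as the compounds shown leave unanswered how a 3-aminophenyl or 3-carboxyphenyl group would read at this place, and how the chlorinated phenyl groups would read on the core of compound 1.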